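The source may report more compounds than this note shows. Statements on the series, on what has been measured and on what is new or still open speak of the compounds shown alone.

Measured so far in a functional assay on SK-OV-3 cells (Homo sapiens) for cytotoxicity, read by sulforhodamine B assay, with a stated time of 48 h, tested at 1 uM; a lower number here means a stronger effect, a higher number a weaker effect of the compound at the concentration tested:

compound 1 `COc1cc(C)cc(-c2nn(CC#N)cc2-c2ccc(-c3cccc(C(C)=O)c3)nc2)c1` gives -4%
compound 2 `Cc1cc(O)cc(-c2nn(CC#N)cc2-c2ccnc(-c3ccc(Oc4ccccc4)cc3)c2)c1` gives 63%

Compound 2 stands at the highest of the two numbers, that is at the weaker end of the pair in this assay. Its nearest neighbour is compound 1, and the two values lie apart by a gap that is beyond the usual scatter. For the measured compounds named here, no single-point step between the two measured compounds is available, as they differ in more than one place, so the pair gives only the two values, not a step.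

The next compound, compound 3 `Cc1cc(O)cc(-c2nn(CC#N)cc2-c2ccnc(-c3ccc(N(C)C)cc3)c2)c1`, keeps everything of compound 2 except one group on the outer aromatic ring: dimethylamino in place of phenoxy on an aromatic carbon. The phenoxy leaves and dimethylamino enters, para to a large group.

Going by the values given here, no measured step covers this change, so its size and direction in this assay are open; a moderate step in either direction, or none beyond the scatter, all remain possible. As the working expectation, compound 3 is estimated at 55% in this assay, with a range from 15% to 95%, which means an expected step of a number 8 percentage points lower from compound 2 to compound 3 (within the scatter).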

Compound 3, a percentage reported as activity, at one concentration (the size of the read-out at that concentration, not a potency): -11%
Compound 3: middle estimate off by 66 percentage points, on the high side; measured number outside the range, below it.
By their numbers in this assay, from the lowest: compounds 3 and 1 (each within the scatter of the next); then compound 2.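

In this assay the aromatic carbon para to a large group turns out to be a sensitive place: with the rest of the structure unchanged, dimethylamino in place of phenoxy gives a number 74 percentage points lower from compound 2 to compound 3 (beyond the scatter) and so this one group separates a weak effect from a strong one at the concentration tested. The change takes away a six-membered aromatic ring of carbon only and goes from 7 heavy atoms to 3, while the count of hydrogen-bond acceptors in the group stays the same, so the step goes with a loss of ring and size and not with a different acceptor count. Nothing measured here ties the step to a particular property of either group.

From the compounds shown here alone, this single step cannot separate the loss of the phenyl ring from the arrival of the amine nitrogen, so it remains open whether a methoxy group, a morpholine or a plain hydrogen at this carbon would keep the effect seen with compound 3. Going by these compounds, it is also open whether the same exchange would give a step of similar size on the core of compound 1.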